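Sulfur oxidation and bromine position on a shared core

A few compounds are considered here, and "the series" means these few. Any claim that something is new, unique, unknown or untested is made for them only; others in the source may bear on it.

Measured so far:
compound 1 `CCCCN(O)C(=O)Nc1cc([C@@H]2CC[C@@H](c3cc(OC)c(OC)c(OC)c3)O2)cc(OC)c1OCCSc1ccc(Br)cc1`: 3%
compound 2 `CCCCN(O)C(=O)Nc1cc([C@@H]2CC[C@@H](c3cc(OC)c(OC)c(OC)c3)O2)cc(OC)c1OCCSc1cccc(Br)c1`: 40%

In a functional assay on the whole organism for inhibition, with Mus musculus as the target, at a dose of 3 mg/kg (a higher number here means more inhibition at the dose given (going by the name of the read-out), a lower number less inhibition), compound 2 gives 40%, the higher of the two numbers, and compound 1 gives 3%. For the measured compounds named here, the one measured step, a number 37 percentage points higher from compound 1 to compound 2 (beyond the scatter), was large. Compound 3 `CCCCN(O)C(=O)Nc1cc([C@@H]2CC[C@@H](c3cc(OC)c(OC)c(OC)c3)O2)cc(OC)c1OCCS(=O)(=O)c1ccc(Br)cc1` carries the change ((4-bromophenyl)sulfonyl in place of (3-bromophenyl)sulfanyl on a saturated chain carbon, two bonds along the chain from an oxygen on an aromatic ring). Going by the values given here, the bromine returns to the position of compound 1, which argues for a fall; the sulfanyl-to-sulfonyl part has no measured counterpart, so its effect is unknown. A drop toward compound 1 is expected, a number 25 percentage points lower from compound 2 to compound 3 (beyond the scatter), giving compound 3 an estimated 15%, between 0% and 40%.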

Compound 3, a percentage reported as inhibition, in the whole organism at one dose (the size of the read-out at that dose, not a potency): 35%
For compound 3 the middle estimate is 20 percentage points below the measured one; measured number inside the range.
By their numbers in this assay, from the lowest: compound 1; then compounds 3 and 2 (each within the scatter of the next).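

In this assay, putting (4-bromophenyl)sulfonyl in place of (4-bromophenyl)sulfanyl gives a number 32 percentage points higher from compound 1 to compound 3 (beyond the scatter) and shows that the 4-bromophenyl group alone does not fix the low number of compound 1. The other change gives a number 5 percentage points lower from compound 2 to compound 3 (within the scatter) and moves the bromine and oxidizes the sulfur together, so this step cannot separate their contributions. Nothing available explains why the sulfonyl group changes the result.

A (3-bromophenyl)sulfonyl group would show whether the two changes add up. As far as these compounds go, it also remains open how a sulfinyl link, or an amine in place of the bromine, would fare.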